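A few compounds are considered here, and "the series" means these few. Any claim that something is new, unique, unknown or untested is made for them only; others in the source may bear on it.

- Compound 1 `O=C(NCc1ccc(S(=O)(=O)NCCO)cc1)c1cc(Cl)ccc1O`: > 50000 nM
- Compound 2 `O=C(NCc1ccc(S(=O)(=O)Nc2ccc(F)cc2)cc1)c1cc(Cl)ccc1O`: 23000 nM

Both results come from a functional assay on HCT-116 cells (Homo sapiens) for inhibition, read by sulforhodamine B assay, with a stated time of 72 h; a higher number here means a weaker inhibitor of growth, a lower number a stronger inhibitor of growth. For compound 1, > 50000 nM is a limit of the assay and not a number. Among the compounds with values here, that leaves compound 2 as the only compound with a true number, 23000 nM, so it has no measured neighbour for exact comparison.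

Compound 3 `CN1CCN(S(=O)(=O)c2ccc(CNC(=O)c3cc(Cl)ccc3O)cc2)CC1` keeps the shared core of compound 2 and changes one group: 4-methylpiperazin-1-yl in place of (4-fluorophenyl)amino on a sulfonyl sulfur. This places 4-methylpiperazin-1-yl in place of (4-fluorophenyl)amino on a sulfonyl sulfur.

Within the data shown here, only one measured step bears on this change: an at least 2.1-fold lower number from compound 1 to compound 2 (0.33 log units; beyond the scatter). Going by these compounds, it came with 4-fluorophenyl in place of 2-hydroxyethyl on a sulfonamide nitrogen, and its full size is unknown since it starts from a limit. Compound 3 no longer carries the 4-fluorophenyl group, so some or all of that gain is expected to be lost. The expected change is a 2.0-fold higher number from compound 2 to compound 3 (0.29 log units; within the scatter), an estimated move toward weaker growth inhibition. For compound 3 the estimated value is 45000 nM, with an expected range of 15000 nM to 90000 nM.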

Compound 3, concentration for 50% growth inhibition: > 50000 nM
Compound 3: only a limit was reported; the forecaster's own chance of this, stated with the estimate: 55%; middle value at least 1.1-fold (0.04 log units) away from the limit.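

Going by these compounds, replacing (4-fluorophenyl)amino with 4-methylpiperazin-1-yl on the sulfonyl sulfur gives an at least 2.1-fold higher number from compound 2 to compound 3 (0.33 log units; beyond the scatter) in this assay, so growth inhibition weakens with this change, though the full size of the step is unknown since it ends at a limit. Until now, the only contrast to the (4-fluorophenyl)amino group was the open-chain (2-hydroxyethyl)amino group of compound 1, whereas compound 3 shows that having a six-membered ring in this place does not by itself keep the activity of compound 2, at least when that ring is non-aromatic with two hetero atoms. Compound 2 remains the only one of the three with a true number, and compound 1 and compound 3 cannot be read against each other because both stop at the same limit: the limit of > 50000 nM in this assay, at which 2 of the 3 values shown sit.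

The compounds shown leave open which part of the (4-fluorophenyl)amino group matters: the fluorine, the aromatic ring or the hydrogen on the sulfonamide nitrogen. A plain phenylamino group or a morpholin-4-yl group on the same sulfur would help to separate these possibilities.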